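Swapping an aminophenyl for a fluorophenyl on the carbonyl

The compounds below may be only part of what the source reports. "The series", "measured", "known", "first", "only" and "open" are said of these compounds alone.

Three compounds share one core and differ only in the ring attached to the carbonyl carbon. In a functional assay on MDA-MB-231 cells (Homo sapiens) for cytotoxicity, read by MTT assay, with a stated time of 48 h (on this read-out lower numbers stand for stronger inhibition and higher numbers for weaker inhibition), compound 1 `O=C(/C=C/c1ccc2c(c1)B(O)OC2)c1cccnc1` gives 11400 nM, compound 2 `O=C(/C=C/c1ccc2c(c1)B(O)OC2)c1ccc(Cl)cc1` gives 7900 nM, and compound 3 `Nc1ccc(C(=O)/C=C/c2ccc3c(c2)B(O)OC3)cc1` gives 25800 nM, the highest number of the three. Compound 4 `O=C(/C=C/c1ccc2c(c1)B(O)OC2)c1ccccc1F` carries the change (2-fluorophenyl in place of 4-aminophenyl on a carbonyl carbon). The measured step that bears most directly on this is a 3.3-fold higher number from compound 2 to compound 3 (0.51 log units; beyond the scatter), where chloro gave way to amino; the change here runs the other way, from amino to a halogen, so a lower number is expected, and a 2.3-fold higher number from compound 1 to compound 3 (0.35 log units; beyond the scatter) points in the same direction. Compound 4 is therefore expected to give about 9000 nM, between 4000 nM and 20000 nM. The expected step is a 2.9-fold lower number from compound 3 to compound 4 (0.46 log units; beyond the scatter).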

Compound 4, half-maximal inhibitory concentration: 2200 nM
Compound 4: the middle estimate sits 4.1-fold (0.61 log units) above what was measured, outside the stated range (below it).
By their numbers in this assay, from the lowest: compound 4; then compounds 2 and 1 (each within the scatter of the next); then compound 3.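

Going by these compounds alone, the ring on the carbonyl carbon can shift this read-out much further than the earlier compounds showed: 2-fluorophenyl in place of 4-aminophenyl gives a 12-fold lower number from compound 3 to compound 4 (1.07 log units; beyond the scatter) here. The gain does not rest on losing the amino group alone, since the 2-fluorophenyl ring also outdoes two rings without it, with a 3.6-fold lower number from compound 2 to compound 4 (0.56 log units; beyond the scatter) and a 5.2-fold lower number from compound 1 to compound 4 (0.71 log units; beyond the scatter) as well. No measurement at hand explains why this ring does so well.

On these data alone, what stays open is whether fluorine itself matters, or whether another group on that ring, such as methoxy or trifluoromethyl, would serve equally well.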